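A few compounds are considered here, and "the series" means these few. Any claim that something is new, unique, unknown or untested is made for them only; others in the source may bear on it.

Values in a functional assay on MCF cells (Homo sapiens) for antiproliferative activity, with a stated time of 72 h (on this read-out higher numbers stand for weaker inhibition and lower numbers for stronger inhibition), so far:
Compound 1 `OC[C@H]1O[C@@H](n2cnc3c(NCc4ccc(Cl)cc4)ncnc32)[C@H](O)[C@@H]1O` gives > 166000 nM (a limit)
Compound 2 `Cc1cccc(CNc2ncnc3c2ncn3[C@@H]2O[C@H](CO)[C@@H](O)[C@H]2O)c1` gives > 166000 nM (a limit)

Compound 2 therefore stands at a limit and has no exact number. Compound 3 `COc1cccc(CNc2ncnc3c2ncn3[C@@H]2O[C@H](CO)[C@@H](O)[C@H]2O)c1` carries methoxy in place of methyl on an aromatic carbon. Among the measured compounds shown here, the only measured step is a step that the two limits leave unreadable from compound 1 to compound 2 and gives no size to carry over. Compound 1 and compound 2 both rest on the limit of > 166000 nM in this assay, at which 2 of the 2 values shown sit, with no exact number for either. In this assay no step beyond the scatter is expected, and another limit is the likeliest report. The expected step is a step that the limit leaves unreadable from compound 2 to compound 3 in size. Compound 3 is estimated at 170000 nM with an expected range from 80000 nM to 300000 nM at its upper end.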

Compound 3, half-maximal inhibitory concentration: > 166000 nM
Compound 3 gave a limit, no number; the forecaster's own chance of this, stated with the estimate: 80%; the middle value is on the limit's open side.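

Among the compounds shown here, no step among compound 1, compound 2 and compound 3 can be read, since each result is only a limit: the limit of > 166000 nM in this assay, at which 3 of the 3 values shown sit. As far as these compounds go, whether methyl, methoxy or chloro changes the activity at all stays open.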